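The compounds below may be only part of what the source reports. "The series", "measured", "known", "first", "only" and "open" are said of these compounds alone.

Working notes on the series.

The three measured compounds share a core and are compared in a toxicity assay on HeLa cells (Homo sapiens) for cytotoxicity, read by MTT assay, with a stated time of 24 h; on this read-out lower numbers stand for stronger inhibition and higher numbers for weaker inhibition. Compound 1 `Cc1ncc([N+](=O)[O-])n1CC(O)CSC(=S)N1CCN(c2ccccc2F)CC1` gives 3240000 nM in this assay. Compound 2 `Cc1ncc([N+](=O)[O-])n1CC(O)CSC(=S)N1CCCC1` gives 1340000 nM in this assay. Compound 3 `CCN1CCN(CC(O)Cn2c([N+](=O)[O-])cnc2C)CC1` gives 4940000 nM in this assay. On these numbers compound 3 sits at the upper end of the set: its value and that of compound 1 lie within the scatter of each other, whereas compound 2 gives a number that is beyond the scatter lower than that of compound 3.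

The next compound is compound 4 `Cc1ncc([N+](=O)[O-])n1CC(O)CN1CCN(c2cccc(Cl)c2)CC1`. The change from compound 3 is 3-chlorophenyl in place of ethyl on an amine nitrogen in a ring. For the measured compounds named here, no pair of measured compounds differs by this change, so the step has no direct precedent; compound 1 also carries an aryl group on a ring amine nitrogen, but through a different linker, and its value to compound 3 is within the scatter. For compound 4 in this assay a modest downward step is expected, a 2.0-fold lower number from compound 3 to compound 4 (0.30 log units; within the scatter), not clearly beyond the scatter. Compound 4 is estimated at 2500000 nM, with a range from 800000 nM to 8000000 nM.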

Compound 4, half-maximal inhibitory concentration: 1440000 nM
Estimate against measurement, compound 4: 1.7-fold (0.24 log units) above, within the range that was stated.
By their numbers in this assay, from the lowest: compounds 2 and 4 (each within the scatter of the next); then compounds 1 and 3 (each within the scatter of the next).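

At this amine nitrogen in a ring, 3-chlorophenyl in place of ethyl gives a 3.4-fold lower number from compound 3 to compound 4 (0.54 log units; beyond the scatter) in this assay and this lies beyond the scatter. For the compounds shown here, it is the first step between compounds that differ in one place, and it shows that the number responds to what this ring nitrogen carries. The entering group brings more heavy atoms and an aromatic ring of carbon only, but nothing measured on these compounds accounts for the lower number.

As far as these compounds go, what stays open is whether the aromatic ring or the chlorine goes with the step, which a plain phenyl group on the same nitrogen would help to separate. From the compounds shown here alone, it is also open how a longer alkyl chain, a benzyl group or a carboxylic acid would read at this position.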